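Diethoxyphenyl in place of dihydroxyphenyl: working notes

This account rests on a few compounds, and the source may have more. Where it says the series, first, only, none or still open, it means among the compounds named here.

- Compound 1 `COc1cc(/C=C/C(=O)C(=Cc2ccc(OC)c(OC)c2)C(=O)/C=C/c2ccc(O)c(OC)c2)ccc1O` in a functional assay, read by spectrophotometry, with a stated time of 5 min (on this read-out higher numbers stand for weaker inhibition and lower numbers for stronger inhibition), gives 71000000 nM
- Compound 2 `COc1cc(/C=C/C(=O)C(=Cc2ccc(O)c(O)c2)C(=O)/C=C/c2ccc(O)c(OC)c2)ccc1O` in this assay gives 10400000 nM

Going by the values given here, of the two numbers so far, compound 2 holds the lower at 10400000 nM and its only neighbour is compound 1 at 71000000 nM on the same read-out. The next structure is compound 3 `CCOc1ccc(C=C(C(=O)/C=C/c2ccc(O)c(OC)c2)C(=O)/C=C/c2ccc(O)c(OC)c2)cc1OCC` and it differs from compound 2 at one place: 3,4-diethoxyphenyl in place of 3,4-dihydroxyphenyl on a double-bonded chain carbon bound to a double-bonded chain carbon with 3,4-diethoxyphenyl in place of 3,4-dihydroxyphenyl on a double-bonded chain carbon bound to a double-bonded chain carbon.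

Among the compounds with values here, one measured step bears on this, at the same place: a 6.8-fold lower number from compound 1 to compound 2 (0.83 log units; beyond the scatter) and it lies beyond the scatter. Compound 1 carries 3,4-dimethoxyphenyl there, the nearest measured group to 3,4-diethoxyphenyl, so the change is expected to run roughly as that step in reverse. This rests on a single pair, and no ethoxy group has been measured. The expected move is a 5.3-fold higher number from compound 2 to compound 3 (0.72 log units; beyond the scatter) in this assay and so toward a higher number and weaker inhibition, of similar size to the measured step. Compound 3 is estimated at 55000000 nM with 14000000 nM to 200000000 nM as the expected range.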

Compound 3, half-maximal inhibitory concentration: 73000000 nM
Compound 3: middle estimate off by 1.3-fold (0.12 log units), on the low side; the measured number falls inside the stated range.
By their numbers in this assay, from the lowest: compound 2; then compounds 1 and 3 (each within the scatter of the next).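

In this assay, going by these compounds alone, the step to 3,4-diethoxyphenyl (a 7.0-fold higher number from compound 2 to compound 3 (0.85 log units; beyond the scatter)) shows that the lower number of compound 2 does not survive a second replacement of its 3,4-dihydroxyphenyl group, so this result no longer rests on the single pair involving 3,4-dimethoxyphenyl. The two ether-bearing groups cannot be told apart at this place, on a double-bonded chain carbon bound to a double-bonded chain carbon (a 1.0-fold higher number from compound 1 to compound 3 (0.01 log units; within the scatter)), and lengthening methoxy to ethoxy therefore registers no separation on this read-out, leaving compound 2 as the only one of the three that stands apart. No measurement is available here that accounts for this separation.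

Still open, as far as these compounds go, is whether both hydroxyl groups are needed, which a phenyl group carrying one hydroxyl and one methoxy, or a single hydroxyl alone, would address. Also open, from the compounds shown here alone, is how this place responds to groups of another kind, such as an amine or a carboxylic acid on the phenyl group, or to longer chains such as propoxy, and whether the flat reading across methoxy and ethoxy extends to them.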